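A Bromo in Place of a Methyl on Compound 3

The compounds below may be only part of what the source reports. "The series", "measured", "known", "first", "only" and "open" are said of these compounds alone.

Measured in a functional assay on MT4 cells (Homo sapiens), read by MTT assay; a lower number here means that less compound is tolerated, a higher number that more compound is tolerated:
- compound 1 `C#C[C@]1(CO)OC(N2C=CC(N)NC2=O)[C@@H](O)[C@@H]1O`: 1740 nM
- compound 2 `C#C[C@]1(CO)O[C@@H](n2cc(F)c(=O)[nH]c2=O)C[C@@H]1O`: 3400 nM
- compound 3 `C#C[C@]1(CO)O[C@@H](n2cc(C)c(N)nc2=O)C[C@@H]1O`: 700 nM

Among these, compound 3, at 700 nM, has the lowest number, and its gaps to compound 1 and compound 2 both lie beyond the usual scatter. Compound 4 `C#C[C@]1(CO)O[C@@H](n2cc(Br)c(N)nc2=O)C[C@@H]1O` differs from compound 3 in one place: bromo in place of methyl on an aromatic carbon. Within the data shown here, no two measured compounds differ by a single change, so the data give no direct guide to this swap. In this assay, the step of a 1.4-fold higher number from compound 3 to compound 4 (0.15 log units; within the scatter) is expected to stay within the scatter, leaning slightly toward a higher number. For compound 4 the estimated value is 1000 nM, with an expected range of 300 nM to 4000 nM.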

Compound 4, half-maximal cytotoxic concentration: > 100000 nM
Compound 4: a limit, no number; the forecaster's own chance of this, stated with the estimate: 10%; middle value at least 100-fold (2.00 log units) from the limit.
By their numbers in this assay, from the lowest: compound 3; then compounds 1 and 2 (each within the scatter of the next). At a limit, above all of these: compound 4.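

In this assay, this single swap on an aromatic carbon ortho to an amino group is a large change: bromo in place of methyl gives an at least 140-fold higher number from compound 3 to compound 4 (2.15 log units; beyond the scatter). Compound 4 gives > 100000 nM, which is a limit of the assay and not a number. Among these compounds, one heavy atom at this position can therefore shift how much compound the cells tolerate, something the earlier compounds, which differ in more than one place, could not show.

Still open, from the compounds shown here alone, is whether chloro or an ethyl group at this position would behave like bromo or like methyl. Also open, going by these compounds, is whether the same swap acts alike on the cores of compound 1 and compound 2.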